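From pyridin-4-yl to pyridin-3-yl at the assay limit

A few compounds are considered here, and "the series" means these few. Any claim that something is new, unique, unknown or untested is made for them only; others in the source may bear on it.

- compound 1 `c1cncc(CNc2ncccc2-c2nnc(Nc3ccc4c(c3)OCCO4)o2)c1`: 13 nM
- compound 2 `c1ccc(-c2nnc(Nc3ccc4c(c3)OCCO4)o2)c(NCc2ccncc2)c1`: 9 nM
- compound 3 `c1ccc(-c2nnc(Nc3ccc4c(c3)OCCO4)[nH]2)c(NCc2ccncc2)c1`: > 10000 nM (a limit of the assay, not a number)

In a functional assay on A-431 cells (Homo sapiens), read by propidium iodide staining, with a stated time of 24 h (on this read-out higher numbers stand for an effect only at larger amounts of compound and lower numbers for an effect already at smaller amounts), compound 1 gives 13 nM and compound 2 gives 9 nM, two values within the usual scatter of each other. Compound 3 has no number, only a limit: it sits at the limit of > 10000 nM in this assay, at which 1 of the 3 values shown sits.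

Compound 4 `c1cncc(CNc2ccccc2-c2nnc(Nc3ccc4c(c3)OCCO4)[nH]2)c1` differs from compound 3 in one place: pyridin-3-yl in place of pyridin-4-yl on a saturated chain carbon bound to a nitrogen on an aromatic ring. Put simply, pyridin-3-yl stands in place of pyridin-4-yl on a saturated chain carbon bound to a nitrogen on an aromatic ring. Within the data shown here, no measured pair shows this swap on its own, so its size can only be estimated. The closest guide is compound 3, with > 10000 nM, and a reading at or close to that limit is expected. Compound 1 also carries pyridin-3-yl and gives 13 nM, which leaves some room for a lower number. The estimated change is a number no higher from compound 3 to compound 4 (the limit leaves the size open), expected to be small and, if visible at all, towards lower numbers. For compound 4 the estimate is 10000 nM, with an expected range from 2500 nM to 20000 nM.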

Compound 4, half-maximal effective concentration: > 10000 nM
Compound 4 ended at the assay's limit (the forecaster's own chance of this, stated with the estimate: 70%); the middle value lies on the limit itself.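

In this assay compound 3 gives > 10000 nM, a limit and not a number. Among these compounds, compound 4 gives > 10000 nM, also a limit, so no step between these two compounds can be read. On these data alone, what pyridin-3-yl in place of pyridin-4-yl does on its own stays open.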